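Fluoro in place of hydrogen on compound 1

This account rests on a few compounds, and the source may have more. Where it says the series, first, only, none or still open, it means among the compounds named here.

Compound 1 `O=C1Nc2ccccc2/C1=N\c1nc(NC2CC2)c2ncn(C3C=CC(CO)C3)c2n1` is one of three compounds sharing a core. In a functional assay on CCRF-CEM cells (Homo sapiens) for cytotoxicity (a lower number here means that less compound is tolerated, a higher number that more compound is tolerated), compound 1 gives 48000 nM, and compound 3 `C/C(=N\c1nc(NC2CC2)c2ncn(C3C=CC(CO)C3)c2n1)c1ccc(O)cc1` gives 62000 nM, the two within the usual scatter of each other. Compound 2 `Cc1ccc(/C=N/c2nc(NC3CC3)c3ncn(C4C=CC(CO)C4)c3n2)cc1` reaches only a limit in this assay, > 100000 nM. Within the data shown here, the single measured step, an at least 1.6-fold lower number from compound 2 to compound 3 (0.20 log units; that floor lies within the scatter), concerns a different part of the molecule and rests on a limit (the limit of > 100000 nM in this assay, at which 1 of the 3 values shown sits).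

Compound 4 `O=C1Nc2ccc(F)cc2/C1=N\c1nc(NC2CC2)c2ncn(C3C=CC(CO)C3)c2n1` differs from compound 1 by fluoro in place of hydrogen on an aromatic carbon. Among the measured compounds shown here, no measured step touches this position, so the change is expected to stay within the scatter: no change at the digits printed from compound 1 to compound 4 (within the scatter). Compound 4 is therefore estimated at 48000 nM in this assay, between 20000 nM and 100000 nM.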

Compound 4, half-maximal cytotoxic concentration: 56000 nM
Compound 4: the middle estimate sits 1.2-fold (0.07 log units) below what was measured, and the stated range covers the measured number.
By their numbers in this assay, from the lowest: compounds 1, 4 and 3 (each within the scatter of the next). At a limit, above all of these: compound 2.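

The earlier compounds shown here held no step at this position; fluoro in place of hydrogen on this aromatic carbon now gives a 1.2-fold higher number from compound 1 to compound 4 (0.07 log units; within the scatter) in this assay. Exchanging hydrogen for fluoro here therefore leaves the read-out within the scatter, at least for this one group on the core of compound 1. Nothing shown bears on why this is so.

On these data alone, whether a methoxy group, an amine or a carboxylic acid on this same carbon would also stay within the scatter remains open. So does the effect of fluoro on the other carbons of this ring.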